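Swapping the aryl ether of compound 2 for an acetamido group

This account rests on a few compounds, and the source may have more. Where it says the series, first, only, none or still open, it means among the compounds named here.

Compound 1 `N#Cc1c(N)nc(SCC(N)=O)c(C#N)c1-c1ccc(OCC2CC2)cc1`: 31%
Compound 2 `N#Cc1c(N)nc(SCC(N)=O)c(C#N)c1-c1ccc(OCC2CCC2)cc1`: 1%
Compound 3 `COC(=O)CSc1nc(N)c(C#N)c(-c2ccc(OCC3CC3)cc2)c1C#N`: 23%

In an assay on CHO cells for displacement of a labelled ligand from adenosine receptor A1 (Homo sapiens), read by scintillation counting, with a stated time of 90 min, tested at 1 uM (on this read-out lower numbers stand for less inhibition and higher numbers for more inhibition at the one concentration tested (going by the name of the read-out)), compound 2 gives 1%, the lowest of the three numbers. Its nearest neighbour is compound 3, which gives 23%, and the highest is compound 1 with 31%; both gaps to compound 2 lie beyond the scatter. The unmeasured compound 4 `CC(=O)Nc1ccc(-c2c(C#N)c(N)nc(SCC(N)=O)c2C#N)cc1` differs from compound 2 at the aromatic carbon of the six-membered carbon ring: acetamido in place of cyclobutylmethoxy on an aromatic carbon.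

Among the measured compounds shown here, only one measured step touches this part of the molecule, the change in ring size within the ether chain, which gave a number 30 percentage points lower from compound 1 to compound 2 (beyond the scatter). The other step, at the carbonyl carbon of the side chain, gave a number 8 percentage points lower from compound 1 to compound 3 (within the scatter) and says nothing about the aryl substituent. Neither step involves a group like acetamido, which brings a hydrogen-bond donor where the ether had none, so the direction of the change cannot be read from a close precedent. Since compound 2 already sits at the bottom of the read-out, any step beyond the scatter can only go upward; a modest rise is therefore expected, giving a number 14 percentage points higher from compound 2 to compound 4 (beyond the scatter), with wide uncertainty. Compound 4 is estimated at 15%, within 0% to 45%.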

Compound 4, a percentage reported as inhibition, at one concentration (the size of the read-out at that concentration, not a potency): 17%
Beside the measured number, compound 4's estimate is 2 percentage points below it, and the stated range covers the measured number.
By their numbers in this assay, from the lowest: compound 2; then compounds 4, 3 and 1 (each within the scatter of the next, the first and the last beyond it).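

In this assay, the group on this aromatic carbon need not be an alkoxy chain carrying a ring: acetamido in place of cyclobutylmethoxy gives a number 16 percentage points higher from compound 2 to compound 4 (beyond the scatter), while acetamido in place of cyclopropylmethoxy gives a number 14 percentage points lower from compound 1 to compound 4 (beyond the scatter). The same acetamido group therefore reads as a gain against one ether and a loss against the other, so the change has no single direction at this position and its sign depends on the ether taken as the reference. No measurement available here accounts for either step, or for compound 4 falling inside the span set by the two ethers.

The compounds shown leave open whether the acetamido result belongs to the amide hydrogen, the carbonyl or the absence of a ring, which a plain amine, a methoxy group or a longer chain ending in an amide on this aromatic carbon could begin to separate. Also open, on these data alone, is whether acetamido would give a similar number when paired with the methyl ester side chain of compound 3.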